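Swapping the Aryl Group on a Ring Nitrogen

The source may hold more compounds than are shown below. What is called first, only, known or untested is meant among the compounds shown, and "the series" means these compounds.

Compound 1, `N#CC1=C(N)Oc2c(c3nc4ccccc4nc3c3ccccc23)C12C(=O)N(Cc1cnnn1-c1ccccc1Br)c1ccccc12`: > 50000 nM
Compound 2, `Cc1ccc(-n2nncc2CN2C(=O)C3(C(C#N)=C(N)Oc4c(N)cc5nc6ccccc6nc5c43)c3ccccc32)cc1C`: > 50000 nM

Both values come from a functional assay on MCF7 cells (Homo sapiens) for antiproliferative activity, read by MTT assay, with a stated time of 48 h; a higher number here means a weaker inhibitor, a lower number a stronger inhibitor. Compound 1 reaches only the limit of the measurement, > 50000 nM, so it carries no number. Compound 2 likewise stops at the limit, > 50000 nM, and the evidence shows (the limit of > 50000 nM in this assay, at which 2 of the 2 values shown sit). Going by the values given here, compound 2 thus stands at the limit rather than at a measured number, and the only other value shown is a limit as well. Among the compounds with values here, no step between measured compounds that differ in one place is available; the two compounds differ in more than one place, and both sit at the limit.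

Compound 3, `COc1cc(-n2nncc2CN2C(=O)C3(C(C#N)=C(N)Oc4c(N)cc5nc6ccccc6nc5c43)c3ccccc32)c(OC)cc1Cl`, is still to be measured. It differs from compound 2 by 4-chloro-2,5-dimethoxyphenyl in place of 3,4-dimethylphenyl on an aromatic nitrogen. Without a measured step to lean on, the expected change is a step that the limit leaves unreadable from compound 2 to compound 3, that is, none beyond the scatter. Compound 3 is estimated at 60000 nM, between 20000 nM and 200000 nM, and it is expected most likely to be reported only as a limit as well.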

Compound 3, half-maximal inhibitory concentration: > 50000 nM
Compound 3 gave a limit, no number; the forecaster's own chance of this, stated with the estimate: 85%; the middle value is on the limit's open side.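

In this assay compound 3 gives > 50000 nM, which is a limit and not a number. No step can be read between compound 2 and compound 3, as both stop at the same limit: the limit of > 50000 nM in this assay, at which 3 of the 3 values shown sit.

The compounds shown leave open whether 4-chloro-2,5-dimethoxyphenyl in place of 3,4-dimethylphenyl changes the antiproliferative activity at all.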